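Growth inhibition series: the methoxy to hydroxy step

The source may report more compounds than this note shows. Statements on the series, on what has been measured and on what is new or still open speak of the compounds shown alone.

- compound 1 `COc1ccc(/C=C/C2(C)C=CC(=O)O2)cc1OC`: 176000 nM
- compound 2 `COc1ccc(/C=C/C2(C)C=CC(=O)O2)c(OC)c1OC`: 90000 nM

Among the measured compounds shown here, in a functional assay on PC-3 cells (Homo sapiens) for inhibition, read by sulforhodamine B assay, with a stated time of 48 h (on this read-out lower numbers stand for stronger inhibition of growth and higher numbers for weaker inhibition of growth), compound 2 gives 90000 nM, and it stands within the scatter of the only other measured compound: a 2.0-fold lower number from compound 1 to compound 2 (0.29 log units; within the scatter). Compound 3 `COc1c(O)ccc(/C=C/C2(C)C=CC(=O)O2)c1OC` differs from compound 2 by hydrogen in place of methyl on an oxygen on an aromatic ring, with hydrogen in place of methyl on an oxygen on an aromatic ring. For the measured compounds named here, the single measured step is methoxy in place of hydrogen on an aromatic carbon, a different change, and no measured step covers methoxy to hydroxy. No step beyond the scatter is therefore expected in this assay, and no direction is favoured. The estimated change is a 1.1-fold lower number from compound 2 to compound 3 (0.05 log units; within the scatter). Compound 3 is expected at 80000 nM, with an estimated range of 30000 nM to 200000 nM.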

Compound 3, concentration for total growth inhibition: 131000 nM
For compound 3 the middle estimate is 1.6-fold (0.21 log units) below the measured one; measured number inside the range.
By their numbers in this assay, from the lowest: compounds 2, 3 and 1 (each within the scatter of the next).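

In this assay, among the compounds shown here, the first look at this oxygen on an aromatic ring gives a 1.5-fold higher number from compound 2 to compound 3 (0.16 log units; within the scatter): removing the methyl, methoxy to hydroxy, produces no step beyond the scatter. The earlier step covered only methoxy in place of hydrogen on an aromatic carbon, so this is a separate change at a separate place, and it too stays within the scatter. No available data bear on the reason for this result.

Open, from the compounds shown here alone, is whether a longer chain on this oxygen, such as ethoxy, would give a step beyond the scatter. The same question holds for an amine or a carboxylic acid in place of the methoxy.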